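A few compounds are considered here, and "the series" means these few. Any claim that something is new, unique, unknown or untested is made for them only; others in the source may bear on it.

Compounds measured so far in an assay on SH-EP1 cells for agonist activity at Neuronal acetylcholine receptor; alpha4/beta2 (Homo sapiens), read by FLIPR and calcium flux; a higher number here means a larger maximal response, a lower number a smaller maximal response:

Compound 1, `CCCC(=O)N1CC2CC(C1)N2`, gives 110%.
Compound 2, `O=C(C1CCC1)N1CC2CC(C1)N2`, gives 99%.

Compound 2 stands lowest of the two numbers obtained in this assay; its nearest neighbour is compound 1, whose response lies higher by a step that is beyond the usual scatter. Among the compounds with values here, that single measured step, a number 11 percentage points lower from compound 1 to compound 2 (beyond the scatter), is the only comparison so far. It concerns the same carbonyl carbon at which the next compound differs.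

Compound 3, `C[C@H]1C[C@@H]1C(=O)N1CC2CC(C1)N2`, has not yet been measured. It differs from compound 2 as follows: 2-methylcyclopropyl in place of cyclobutyl on a carbonyl carbon. The two share the same atoms, joined differently, and the group that enters keeps a small carbon ring on the carbonyl carbon.

One modest step, from a propyl chain to a cyclobutyl ring, lowered the response. Moving from a cyclobutyl ring to a 2-methylcyclopropyl ring is expected to shift the response in this assay by no more than the scatter, or by a small amount downward at most, giving an estimated a number 4 percentage points lower from compound 2 to compound 3 (within the scatter). Compound 3 is therefore estimated to give 95%, within a range from 80% to 110%.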

Compound 3, largest response reached (Emax), in percent of the reference or control that the assay uses: 85%
The estimate for compound 3 lay 10 percentage points above the measured number; low and high end bracket the measured number.
By their numbers in this assay, from the lowest: compound 3; then compound 2; then compound 1.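

In this assay, the step of a number 14 percentage points lower from compound 2 to compound 3 (beyond the scatter) shows that the maximal response on this carbonyl carbon depends on more than which atoms are present: cyclobutyl and 2-methylcyclopropyl have the same atoms, joined differently, and yet the two compounds are separated by more than the scatter. The step of a number 25 percentage points lower from compound 1 to compound 3 (beyond the scatter) is the largest among the compounds shown, and it places both ring-bearing groups below propyl, with 2-methylcyclopropyl lowest, so the first drop on replacing propyl with a ring was not the limit of what this position allows. No evidence is available to explain why the 2-methylcyclopropyl group gives the lower response.

The compounds shown leave open whether the methyl group, the three-membered ring or the particular arrangement of the 2 defined stereocentres accounts for the lower response, since these features enter together in a single change. They also leave open how an unsubstituted cyclopropyl group, the opposite stereoisomer of 2-methylcyclopropyl or a longer chain on the same carbonyl carbon would compare.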